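A few compounds are considered here, and "the series" means these few. Any claim that something is new, unique, unknown or untested is made for them only; others in the source may bear on it.

In a functional assay on HUVEC cells (Homo sapiens) (a higher number here means that more compound is needed for the effect, a lower number that less compound is needed), compound 2 (`COC1=C(C)C(=O)/C(=C(O)/C=C/c2c(C)cccc2C)C(=O)C1(C)C`) stands at < 4 ug/mL, a limit of the assay and not a number. Compound 1 (`COC1=C(C)C(=O)/C(=C(O)/C=C/c2ccc(O)cc2)C(=O)C1(C)C`) likewise gives < 4 ug/mL, again a limit. What is known so far is therefore the limit of < 4 ug/mL in this assay, at which 2 of the 2 values shown sit, and no more. The change to compound 3 (`C=Cc1ccccc1/C=C/C(O)=C1/C(=O)C(C)=C(OC)C(C)(C)C1=O`) is 2-vinylphenyl in place of 2,6-dimethylphenyl on a double-bonded chain carbon bound to a double-bonded chain carbon and touches nothing else in the structure. Going by the values given here, the only measured step with any bearing is a step that the two limits leave unreadable from compound 1 to compound 2 and it gives no size to carry over. The expected step, a step that the limit leaves unreadable from compound 2 to compound 3 in this assay, is therefore none beyond the scatter, in either direction. Compound 3 is estimated at 2 ug/mL, with an expected range from 0.6 ug/mL to 6 ug/mL.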

Compound 3, concentration for half-maximal effect: < 1.1 ug/mL
Compound 3 was reported as a limit; the forecaster's own chance of this, stated with the estimate: 60%; at least 1.8-fold (0.25 log units) between middle value and limit.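

Going by these compounds alone, compound 1, compound 2 and compound 3 are all reported only as limits in this assay, so no step among them can be read. As far as these compounds go, whether the three compounds differ at all in this assay stays open.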